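A Methoxy Group Added to Compound 3

The source may report more compounds than this note shows. Statements on the series, on what has been measured and on what is new or still open speak of the compounds shown alone.

Of the compounds shown here, three have been measured so far. In a functional assay on FM3A cells (Mus musculus) for antiproliferative activity, with a stated time of 48 h (on this read-out higher numbers stand for weaker inhibition and lower numbers for stronger inhibition), compound 1 `C=C(Br)C(=O)Nc1ccc(/C=C/C(=O)c2ccc(Cl)c(Cl)c2)cc1` gives 3200 nM and compound 2 `C=C(Br)C(=O)Nc1ccc(/C=C/C(=O)c2cccc3ccccc23)cc1` gives 2400 nM. Compound 3 `C=C(Br)C(=O)Nc1ccc(C(=O)/C=C/c2ccccc2)cc1` gives 690 nM, the lowest of the three numbers and the strongest inhibition in the set, with its gaps to both others lying beyond the scatter.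

Compound 4 `C=C(Br)C(=O)Nc1ccc(C(=O)/C=C/c2ccccc2OC)cc1` departs from compound 3 in a single place, where phenyl becomes 2-methoxyphenyl. This puts methoxy in place of hydrogen on an aromatic carbon, ortho to a large group (methoxy in place of hydrogen on an aromatic carbon).

Going by the values given here, no two measured compounds differ in only one place, so the data offer no direct gauge of this change. The three measured compounds also say nothing specific about a methoxy group. In this assay, the expected step is therefore modest, a 1.2-fold lower number from compound 3 to compound 4 (0.06 log units; within the scatter), with no beyond-scatter change anticipated in either direction. For compound 4, the estimated value is 600 nM, with an expected range from 220 nM to 1600 nM.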

Compound 4, half-maximal inhibitory concentration: 370 nM
Compound 4: middle estimate off by 1.6-fold (0.21 log units), on the high side, within the range that was stated.
By their numbers in this assay, from the lowest: compounds 4 and 3 (each within the scatter of the next); then compounds 2 and 1 (each within the scatter of the next).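

In this assay, going by these compounds alone, this is the first comparison in the set between compounds that differ in one place, and it gives a 1.9-fold lower number from compound 3 to compound 4 (0.27 log units; within the scatter). Methoxy in place of hydrogen on an aromatic carbon, ortho to a large group, is therefore accepted at this position, with 2-methoxyphenyl causing no change beyond the scatter from phenyl. No measurement shown here gives a reason for this outcome.

From the compounds shown here alone, it remains open whether this position would accept an amine, a carboxylic acid or a longer alkoxy chain in the same way. Going by these compounds, it is also open whether methoxy on another carbon of this ring would give a step of similar size, since this one step describes a single group at a single place.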